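Compound 3: a fluorinated group directly on the carbonyl

A few compounds are considered here, and "the series" means these few. Any claim that something is new, unique, unknown or untested is made for them only; others in the source may bear on it.

Compound 1 `Cc1nc(S(C)(=O)=O)ccc1Oc1ncnc(OC2CCN(C(=O)O[C@H](C)CF)CC2)c1F` gives 196 nM in a functional assay on isolated protein for inhibition of Glucose-dependent insulinotropic receptor (Homo sapiens), read by HTRF and cAMP accumulation (on this read-out higher numbers stand for an effect only at larger amounts of compound and lower numbers for an effect already at smaller amounts), the higher of the two measured numbers. For the measured compounds named here, compound 2 `Cc1nc(S(C)(=O)=O)ccc1Oc1ncnc(OC2CCN(C(=O)O[C@@H](C)C(F)(F)F)CC2)c1F` gives 9.86 nM, so the only measured step is a 20-fold lower number from compound 1 to compound 2 (1.30 log units; beyond the scatter). Compound 3 `Cc1nc(S(C)(=O)=O)ccc1Oc1ncnc(OC2CCN(C(=O)C(C)(C)F)CC2)c1F` differs from compound 1 as follows: a group of 4 heavy atoms (3 carbon, 1 fluorine; no ring) in place of a group of 5 heavy atoms (3 carbon, 1 oxygen, 1 fluorine; no ring), on a carbonyl carbon The measured step exchanged one fluorinated group for another on an oxygen next to a carbonyl group; here that oxygen itself leaves, so the step bears on compound 3 only loosely. For compound 3 a moderate move toward lower numbers is expected, a 2.0-fold lower number from compound 1 to compound 3 (0.29 log units; within the scatter), with wide uncertainty. Compound 3 is estimated at 100 nM, within a range from 25 nM to 400 nM.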

Compound 3, half-maximal effective concentration: 76.3 nM
Compound 3: middle estimate off by 1.3-fold (0.12 log units), on the high side, and the stated range covers the measured number.
By their numbers in this assay, from the lowest: compound 2; then compound 3; then compound 1.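

On a carbonyl carbon whose other neighbours are an amide-type nitrogen in a ring, the linking oxygen is not required for activity: removing it with the change to 1-fluoro-1-methylethyl gives a 2.6-fold lower number from compound 1 to compound 3 (0.41 log units; beyond the scatter), while a 7.7-fold higher number from compound 2 to compound 3 (0.89 log units; beyond the scatter) shows that this group does not match 1-(trifluoromethyl)ethoxy. Nothing available explains either step.

Still open, going by these compounds, is how an amine on this carbonyl carbon, or a trifluoromethyl-bearing group attached directly to it, would compare. Separating the effect of the oxygen from that of the fluorine count would need further one-place pairs.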